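This account rests on a few compounds, and the source may have more. Where it says the series, first, only, none or still open, it means among the compounds named here.

Measured so far in a functional assay on SK-MEL-28 cells (Homo sapiens) for inhibition, read by sulforhodamine B assay, with a stated time of 48 h, tested at 100 uM; on this read-out higher numbers stand for a weaker effect at the one concentration tested and lower numbers for a stronger effect: compound 1, `COc1cc(Cl)cc(-c2nn(-c3cccc(NC(=O)Nc4ccc(Cl)c(Cl)c4)c3)cc2-c2ccncc2)c1`, gives -7%; compound 2, `COc1cc(Cl)cc(-c2nn(-c3cccc(NC(=O)Nc4cccc(C(F)(F)F)c4)c3)cc2-c2ccncc2)c1`, gives -25%.

Compound 2 stands lowest of the two numbers in this assay, and its nearest neighbour is compound 1, a number beyond the scatter away. Among the measured compounds shown here, the one measured step, a number 18 percentage points lower from compound 1 to compound 2 (beyond the scatter), exchanged one aryl group for another on an amide-type nitrogen, leaving the carbonyl and its neighbours untouched.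

Compound 3, `COc1cc(Cl)cc(-c2nn(-c3cccc(NC(=O)c4cccc(C(F)(F)F)c4)c3)cc2-c2ccncc2)c1`, differs from compound 2 by 3-(trifluoromethyl)phenyl in place of (3-(trifluoromethyl)phenyl)amino on a carbonyl carbon. For the measured compounds named here, no measured step bears on a change at a carbonyl carbon whose other neighbour is an amide-type nitrogen; the step between compounds 1 and 2 concerns a different position and gives no direction for this one. The step of a number 15 percentage points higher from compound 2 to compound 3 (beyond the scatter) is therefore expected to be small, with no direction claimed beyond the scatter. For compound 3 the estimate in this assay is -10%, with a range from -40% to 20%.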

Compound 3, a percentage reported as activity, at one concentration (the size of the read-out at that concentration, not a potency): 75%
Beside the measured number, compound 3's estimate is 85 percentage points below it; measured number above the stated range.
By their numbers in this assay, from the lowest: compound 2; then compound 1; then compound 3.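

In this assay, the change on the carbonyl carbon, 3-(trifluoromethyl)phenyl in place of (3-(trifluoromethyl)phenyl)amino, gives a large step, a number 100 percentage points higher from compound 2 to compound 3 (beyond the scatter), and so shows that this position matters far more than the modest aryl exchange on the amide-type nitrogen, a number 18 percentage points lower from compound 1 to compound 2 (beyond the scatter). The step of a number 82 percentage points higher from compound 1 to compound 3 (beyond the scatter) is also large, though it changes the aryl substitution as well as removing the amino nitrogen with its hydrogen-bond donor. No measurement at hand explains why removing this nitrogen carries such a large step.

The compounds shown leave open whether the nitrogen itself counts or only the link it provides, since a methylene group or an ether oxygen in its place would separate the two. They also leave open whether 3,4-dichlorophenyl directly on the carbonyl carbon behaves as 3-(trifluoromethyl)phenyl does.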